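Dichloroacetamides: removing one 4-methoxyphenyl from compound 1

A few compounds are considered here, and "the series" means these few. Any claim that something is new, unique, unknown or untested is made for them only; others in the source may bear on it.

Measured so far in a functional assay on NCI-H460 cells (Homo sapiens) for cytotoxicity, read by MTT assay, with a stated time of 68 h; on this read-out lower numbers stand for stronger inhibition and higher numbers for weaker inhibition
Compound 1 (`COc1ccc(-c2cc(NC(=O)C(Cl)Cl)cc(-c3ccc(OC)cc3)c2)cc1`) (> 30000 nM, a limit)
Compound 2 (`CCOc1ccccc1-c1cc(NC(=O)C(Cl)Cl)cc(-c2ccccc2OCC)c1`) (5090 nM)

Compound 1 stands at > 30000 nM in this assay (a limit of the assay, not a number). Among the compounds with values here, compound 2 gives 5090 nM as the only true number so far. Compound 3 (`COc1ccc(-c2cccc(NC(=O)C(Cl)Cl)c2)cc1`) is not yet measured. It differs from compound 1 by hydrogen in place of 4-methoxyphenyl on an aromatic carbon. Within the data shown here, no measured pair isolates this change, and compound 1 offers no number to start from. In this assay a modest move toward lower numbers is therefore expected, possibly none beyond the scatter. The expected step of an at least 1.5-fold lower number from compound 1 to compound 3 (0.17 log units; that floor lies within the scatter) is small. Compound 3 is estimated at 20000 nM (expected range 6000 nM to 60000 nM).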

Compound 3, half-maximal inhibitory concentration: 43300 nM
Compound 3: middle estimate off by 2.2-fold (0.34 log units), on the low side, within the range that was stated.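

No step can be read from compound 1 to compound 3, since the value for compound 1 is a limit and not a number: the limit of > 30000 nM in this assay, at which 1 of the 3 values shown sits.

The compounds shown leave open how far, and in which direction, hydrogen in place of 4-methoxyphenyl on an aromatic carbon moves the number.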